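This account rests on a few compounds, and the source may have more. Where it says the series, first, only, none or still open, it means among the compounds named here.

Three analogues built on one shared core have been tested in a functional assay on PC-3 cells (Homo sapiens) for cytotoxicity, read by MTT assay, with a stated time of 48 h; on this read-out lower numbers stand for stronger inhibition and higher numbers for weaker inhibition. Compound 1 `CNC(=O)c1cc(Oc2cccc(NC(=S)Nc3ccc(Cl)cc3)c2)ccn1` gives 24100 nM, compound 2 `CNC(=O)c1cc(Oc2cccc(NC(=S)Nc3ccc(F)c(F)c3)c2)ccn1` gives 33100 nM, and compound 3 `CNC(=O)c1cc(Oc2cccc(NC(=S)Nc3cccc(C(F)(F)F)c3)c2)ccn1` gives 24500 nM. Compound 3 stands second highest of the three, nearest compound 1 and furthest from compound 2, with every gap within the scatter: a 1.4-fold higher number from compound 1 to compound 2 (0.14 log units; within the scatter), a 1.0-fold higher number from compound 1 to compound 3 (0.01 log units; within the scatter), a 1.4-fold lower number from compound 2 to compound 3 (0.13 log units; within the scatter). Compound 4 `O=C(NC1CC1)c1cc(Oc2cccc(NC(=S)Nc3cccc(C(F)(F)F)c3)c2)ccn1` remains to be measured; it differs from compound 3 by cyclopropyl in place of methyl on an amide-type nitrogen. Within the data shown here, none of the measured steps touches this place, each of them exchanging the aryl group on an amide-type nitrogen elsewhere, and all stayed within the scatter. The expected step in this assay is therefore a 1.0-fold higher number from compound 3 to compound 4 (0.01 log units; within the scatter), nothing beyond the scatter. Compound 4 is expected to give 25000 nM, within 10000 nM to 60000 nM.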

Compound 4, half-maximal inhibitory concentration: 22100 nM
Compound 4: middle estimate off by 1.1-fold (0.05 log units), on the high side, within the range that was stated.
By their numbers in this assay, from the lowest: compounds 4, 1, 3 and 2 (each within the scatter of the next).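

In this assay, cyclopropyl in place of methyl on the amide-type nitrogen whose other neighbour is the carbonyl carbon gives a 1.1-fold lower number from compound 3 to compound 4 (0.04 log units; within the scatter). This is the only step shown at this place, and it shows that a three-membered ring can enter here without a shift beyond the scatter, as also held for the aryl exchanges elsewhere. No supporting measurement bears on this result. Still open, from the compounds shown here alone, is whether a longer chain, a tertiary amine or a carboxylic acid at this place would also stay within the scatter. Also open, going by these compounds, is whether cyclopropyl behaves alike with 4-chlorophenyl or 3,4-difluorophenyl on the other side.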